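A few compounds are considered here, and "the series" means these few. Any claim that something is new, unique, unknown or untested is made for them only; others in the source may bear on it.

Measured compounds:
Compound 1 `CCCCc1cnc(CCCc2ccc(-c3ccccc3C(=O)O)cc2)[nH]1`: in an in vitro functional assay on cells for agonist activity at Bombesin receptor subtype-3 (Mus musculus), read by luminescence and calcium flux (on this read-out lower numbers stand for an effect already at smaller amounts and higher numbers for an effect only at larger amounts of compound), compound 1 gives 382 nM.
Compound 2 `COc1ccc(Cc2cnc(CCc3ccc(-c4ccccc4C(=O)O)cc3)[nH]2)cc1`: in this assay compound 2 gives 513 nM.

Compound 2 stands within the usual scatter of compound 1, so the two numbers show no reliable difference. Compound 3 `CCCCc1cnc(CCc2ccc(-c3ccccc3C(=O)O)cc2)[nH]1` has not been measured. It differs from compound 2 in one place: propyl in place of 4-methoxyphenyl on a saturated chain carbon bound to an aromatic carbon. Going by the values given here, no step between measured compounds covers this change, so the expectation rests on compound 1, because compound 1 gives 382 nM while carrying the same butyl. Compound 3 is expected to give 450 nM, between 150 nM and 1400 nM. The expected step of a 1.1-fold lower number from compound 2 to compound 3 (0.06 log units; within the scatter) is estimated to stay within the scatter, in no clear direction.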

Compound 3, half-maximal effective concentration: 93 nM
Compound 3: the middle estimate sits 4.8-fold (0.68 log units) above what was measured; measured number outside the range, below it.
By their numbers in this assay, from the lowest: compound 3; then compounds 1 and 2 (each within the scatter of the next).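

In this assay, going by these compounds alone, this position proves sensitive to what it carries: going from 4-methoxybenzyl to butyl gives a 5.5-fold lower number from compound 2 to compound 3 (0.74 log units; beyond the scatter) and lies beyond the scatter, which the earlier compounds, differing in more than one place, could not show. The change removes the aromatic ring and the methoxy oxygen together, so this single step cannot separate the two. Nothing measured here accounts for the step.

The compounds shown leave open whether plain benzyl, without the methoxy, would stand nearer butyl or 4-methoxybenzyl. Going by these compounds, how a shorter ethyl or a longer hexyl chain would read at this position also remains open.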